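Urea aryl swap on the shared core: dichloro to trifluoromethyl

The compounds below may be only part of what the source reports. "The series", "measured", "known", "first", "only" and "open" are said of these compounds alone.

Compound 3 `COc1cc(Cl)cc(-c2nn(-c3cccc(NC(=O)Nc4ccc(Cl)c(Cl)c4)c3)cc2-c2ccncc2)c1` gives -7% in a functional assay on SK-MEL-28 cells (Homo sapiens) for inhibition, read by sulforhodamine B assay, with a stated time of 48 h, tested at 100 uM (on this read-out lower numbers stand for a stronger effect and higher numbers for a weaker effect at the one concentration tested), the highest of the three measured numbers, so the weakest effect on this read-out. Compound 1 `COc1cc(Cl)cc(-c2nn(-c3cccc(NC(=O)Nc4ccc(Cl)c(C(F)(F)F)c4)c3)cc2-c2ccncc2)c1` gives -88% in this assay. Compound 2 `COc1cc(Cl)cc(-c2nn(-c3cccc(NC(=O)Nc4cc(C(F)(F)F)cc(C(F)(F)F)c4)c3)cc2-c2ccncc2)c1` gives -58% in this assay. Among the compounds with values here, the one single-point step measured, a number 81 percentage points higher from compound 1 to compound 3 (beyond the scatter), bears directly on the change to compound 4 `COc1cc(Cl)cc(-c2nn(-c3cccc(NC(=O)Nc4cccc(C(F)(F)F)c4)c3)cc2-c2ccncc2)c1`: 3-(trifluoromethyl)phenyl in place of 3,4-dichlorophenyl on an amide-type nitrogen. The trifluoromethyl returns while both chloro groups leave, and nothing in the set shows on its own whether the chloro that also leaves carries weight. Both measured compounds bearing a trifluoromethyl, compound 1 and compound 2, sit far below compound 3, so a downward step beyond the scatter is expected, with the size uncertain.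

Compound 4 is expected near -55% in this assay, within a range from -90% to -5%. That estimate means an expected step of a number 48 percentage points lower from compound 3 to compound 4 (beyond the scatter).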

Compound 4, a percentage reported as activity, at one concentration (the size of the read-out at that concentration, not a potency): -25%
Beside the measured number, compound 4's estimate is 30 percentage points below it; low and high end bracket the measured number.
By their numbers in this assay, from the lowest: compound 1; then compound 2; then compound 4; then compound 3.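

In this assay, a lone trifluoromethyl on the ring at this amide-type nitrogen still gives a stronger effect than the 3,4-dichlorophenyl group, with a number 18 percentage points lower from compound 3 to compound 4 (beyond the scatter) and no chloro present. The second ring substituent also counts: hydrogen in place of chloro gives a number 63 percentage points higher from compound 1 to compound 4 (beyond the scatter) and hydrogen in place of the second trifluoromethyl gives a number 33 percentage points higher from compound 2 to compound 4 (beyond the scatter). Among these compounds, the single trifluoromethyl therefore accounts for only part of the effect seen with compound 1 and compound 2, and either chloro or a second trifluoromethyl adds to it.

No evidence at hand explains these steps. Still open, going by these compounds, is how a ring bearing a single chloro would compare, and whether a nitrile or a carboxylic acid could stand in for the trifluoromethyl.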